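Removing a Core Chloro from Compound 1

The source may hold more compounds than are shown below. What is called first, only, known or untested is meant among the compounds shown, and "the series" means these compounds.

Measured so far:
compound 1 `ClCc1ccc(Cn2cnc3nc(Cl)nc(Cl)c32)cc1` gives 44700 nM in a functional assay on Hs-578T cells (Homo sapiens) for cytotoxicity, read by sulforhodamine B assay, with a stated time of 48 h; on this read-out lower numbers stand for stronger inhibition of growth and higher numbers for weaker inhibition of growth
compound 2 `ClCc1ccccc1Cn1cnc2nc(Cl)nc(Cl)c21` gives 2570 nM in this assay

Compound 1 stands highest of the two numbers, the weaker of the pair; compound 2 lies beyond the scatter away from it. Compound 3 `ClCc1ccc(Cn2cnc3ncnc(Cl)c32)cc1` differs from compound 1 by hydrogen in place of chloro on an aromatic carbon. Among the measured compounds shown here, no measured pair shows what such a removal does here. The step is expected to be small and toward a higher number, near the edge of the scatter. Compound 3 is therefore estimated at 65000 nM, with a range from 20000 nM to 200000 nM, a step of a 1.5-fold higher number from compound 1 to compound 3 (0.16 log units; within the scatter).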

Compound 3, concentration for total growth inhibition: 4260 nM
The estimate for compound 3 lay 15-fold (1.18 log units) above the measured number, outside the stated range (below it).
By their numbers in this assay, from the lowest: compounds 2 and 3 (each within the scatter of the next); then compound 1.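

In this assay, replacing the chloro between two ring nitrogen atoms with hydrogen moves the number down sharply (a 10-fold lower number from compound 1 to compound 3 (1.02 log units; beyond the scatter)), toward stronger inhibition of growth. On the core of compound 1, then, this chloro is not required for the effect on these cells, and this single atom carries a large change. No measurement here explains the size of this step. As far as these compounds go, whether an amine or a methyl group at this position would keep the gain remains open. So does whether removing the same chloro from compound 2 would act alike.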